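The source may report more compounds than this note shows. Statements on the series, on what has been measured and on what is new or still open speak of the compounds shown alone.

Measured so far in a functional assay on IMR-32 cells (Homo sapiens) for inhibition, with a stated time of 48 h, tested at 50 uM; on this read-out higher numbers stand for more inhibition of growth at the one concentration tested and lower numbers for less inhibition of growth:
- compound 1, `C=C[C@@](C)(/C=C/c1ccc(O)c(N)c1)CCC=C(C)C`: 39%
- compound 2, `COc1ccccc1/C=C/[C@@](C)(/C=C/c1ccc(O)cc1)CCC=C(C)C`: 68%
- compound 3, `COc1ccc(/C=C/[C@@](C)(/C=C/c2ccc(O)cc2)CCC=C(C)C)cc1`: 6%

Compound 3 stands lowest of the three numbers in this assay. Among the compounds with values here, its nearest neighbour is compound 1, and its furthest is compound 2; the step of a number 62 percentage points lower from compound 2 to compound 3 (beyond the scatter) is the only single-point change on record, and it is large. That step concerns the position of the methoxy group on the aryl ring and not an added substituent, so it does not speak directly to what follows.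

The next compound is compound 4, `COc1ccc(/C=C/[C@@](C)(/C=C/c2ccc(O)cc2)CCC=C(C)C)cc1C=O`. Relative to compound 3 the change is formyl in place of hydrogen on an aromatic carbon. Within the data shown here, no measured pair shows a formyl entering anywhere, and the one recorded step, the one from compound 2 to compound 3, tells nothing about a new group placed on the ring that already carries the methoxy. There is therefore no basis in the data for expecting a step beyond the scatter in either direction in this assay, and the only anchor is the low standing of compound 3.

On that anchor, compound 4 is expected to give about 15% in this assay, within a range from 0% to 45%; the step this estimate implies is a number 9 percentage points higher from compound 3 to compound 4 (within the scatter), and it is expected to remain close to the scatter.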

Compound 4, percent growth inhibition at one concentration: 35%
The estimate for compound 4 lay 20 percentage points below the measured number; low and high end bracket the measured number.
By their numbers in this assay, from the lowest: compound 3; then compounds 4 and 1 (each within the scatter of the next); then compound 2.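

In this assay, within the data shown here, formyl in place of hydrogen on an aromatic carbon, ortho to a methoxy group and meta to a large group, comes with a number 29 percentage points higher from compound 3 to compound 4 (beyond the scatter) and is the first single-point change on record in which a group enters rather than shifts. The aryl ring of compound 3 therefore responds to a new group as well as to the place of its methoxy, the change seen in a number 62 percentage points lower from compound 2 to compound 3 (beyond the scatter), and the hydrogen at this aromatic carbon can give way to formyl without a further loss of growth inhibition. No measurement of any property accompanies this step, and what lies behind it stays unexplained.

With only formyl on record at this carbon, the step cannot yet be told apart as something particular to formyl or as common to other groups, and a hydroxymethyl, a carboxylic acid or an amine in the same place would separate these readings. Also open, as far as these compounds go, is whether formyl gives a step of like size on the 2-methoxyphenyl ring of compound 2, which would show whether the effect depends on where the methoxy sits.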